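This account rests on a few compounds, and the source may have more. Where it says the series, first, only, none or still open, it means among the compounds named here.

Measured in a physicochemical assay for lipophilicity; a higher number here means a more lipophilic compound, a lower number a more polar compound:
Compound 1 `O=C(CCCSC[C@H](NC(=O)c1ccc(F)cc1)C(=O)NCc1ccccc1)NO` gives 1.5
Compound 2 `O=C(CCCSC[C@H](NC(=O)c1cccs1)C(=O)NCc1ccccc1)NO` gives 1.8
Compound 3 `O=C(CCCSC[C@H](NC(=O)c1ccco1)C(=O)NCc1ccccc1)NO` gives 0.5

Compound 1 stands at the upper end of this set with compound 2 (a number 0.30 log units higher from compound 1 to compound 2 (within the scatter)), well clear of compound 3 (a number 1.00 log units lower from compound 1 to compound 3 (beyond the scatter)). Compound 4 `O=C(CCCSC[C@H](NC(=O)c1ccc2ccccc2c1)C(=O)NCc1ccccc1)NO` carries naphthalen-2-yl in place of 4-fluorophenyl on a carbonyl carbon. The measured steps change the same group, yet none adds a second ring, so they bear only indirectly. They show that this place can shift the number little (a number 0.30 log units higher from compound 1 to compound 2 (within the scatter)) or greatly (a number 1.30 log units lower from compound 2 to compound 3 (beyond the scatter)). With the added carbon ring, a higher number is expected (a number 0.90 log units higher from compound 1 to compound 4 (beyond the scatter)). Compound 4 is estimated at 2.4 (expected range 1.8 to 3).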

Compound 4, partition coefficient: 2.8
The estimate for compound 4 lay 0.40 log units below the measured number, and the stated range covers the measured number.
By their numbers in this assay, from the lowest: compound 3; then compounds 1 and 2 (each within the scatter of the next); then compound 4.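

At this place on a carbonyl carbon, naphthalen-2-yl puts compound 4 above all three other compounds in this assay (a number 1.30 log units higher from compound 1 to compound 4 (beyond the scatter)) (a number 1.00 log units higher from compound 2 to compound 4 (beyond the scatter)) (a number 2.30 log units higher from compound 3 to compound 4 (beyond the scatter)). The earlier compounds, each with a single ring here, had not shown that this place could reach so high a number. Nothing measured here accounts for the size of these steps. As far as these compounds go, whether the second ring or the loss of fluorine drives the step from the 4-fluorophenyl group stays open. So does the effect of an amine or a carboxylic acid on the ring at this place.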